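Clearance after removing the carboxy from compound 3

A few compounds are considered here, and "the series" means these few. Any claim that something is new, unique, unknown or untested is made for them only; others in the source may bear on it.

Measured so far in an ADME assay on microsomes (Homo sapiens) for metabolic stability; a lower number here means slower removal, a higher number faster removal of the compound
Compound 1 `CCc1cc(C(F)(F)F)c2cccc(OCc3c(Cl)ccc(S(=O)(=O)N4CCC[C@H]4C(=O)NC)c3Cl)c2n1` gives 300 mL/min/kg
Compound 2 `CNC(=O)[C@@H]1CCCN1S(=O)(=O)c1cccc(COc2cccc3c(C(F)(F)F)cc(C)nc23)c1` gives 50 mL/min/kg
Compound 3 `Cc1cc(C(F)(F)F)c2cccc(OCc3c(Cl)ccc(S(=O)(=O)N4CCC[C@H]4C(=O)O)c3Cl)c2n1` gives 8.33 mL/min/kg

In this assay compound 3 stands lowest of the three with 8.33 mL/min/kg as its value, and both other compounds lie beyond the scatter from it, compound 2 nearest and compound 1 furthest. The next compound is compound 4 `Cc1cc(C(F)(F)F)c2cccc(OCc3c(Cl)ccc(S(=O)(=O)N4CCCC4)c3Cl)c2n1` and its difference from compound 3 reads hydrogen in place of carboxy on a saturated ring carbon in full. In short, it carries hydrogen in place of carboxy on a saturated ring carbon.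

Going by the values given here, no measured pair differs in one place only, so the size of this step has no direct precedent. Among the compounds with values here, compound 3 is the only measured compound with a carboxy, and the two without it sit higher, compound 2 at 50 mL/min/kg and compound 1 at 300 mL/min/kg on the same scale. Both also differ from compound 3 elsewhere, so this is only a weak guide. On that basis, the expected 11-fold higher number from compound 3 to compound 4 (1.03 log units; beyond the scatter) is a rise beyond the scatter, with its size poorly fixed. For compound 4 the estimated clearance is 90 mL/min/kg with an expected range from 30 mL/min/kg to 250 mL/min/kg in this assay once measured.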

Compound 4, clearance: 233 mL/min/kg
Estimate against measurement, compound 4: 2.6-fold (0.41 log units) below; the range from low to high includes it.
By their numbers in this assay, from the lowest: compound 3; then compound 2; then compounds 4 and 1 (each within the scatter of the next).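

In this assay, going by these compounds alone, the change is read for the first time in one place alone, and the step is large: a 28-fold higher number from compound 3 to compound 4 (1.45 log units; beyond the scatter). The earlier compounds shown here could only hint at this, since compounds 1 and 2 each differ from compound 3 elsewhere as well as at this carbon. This pair ties a rise beyond the scatter to a single position, the saturated ring carbon next to the ring nitrogen, where 2-carboxypyrrolidin-1-yl becomes pyrrolidin-1-yl while the rest of the molecule stays the same. Nothing measured here gives a reason for a step of this size.

The compounds shown leave open how other groups on this ring carbon would compare, for instance a hydroxymethyl, a primary amide, a tetrazole or an acetic acid side chain, and so whether the carboxy is the only group tied to the low number of compound 3. They also leave open whether removing the carboxy would give a step of similar size on a core other than that of compound 3.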